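A few compounds are considered here, and "the series" means these few. Any claim that something is new, unique, unknown or untested is made for them only; others in the source may bear on it.

Compound 1 `C=C(Br)C(=O)Nc1ccc(C(=O)/C=C/c2ccccc2)cc1` gives 1500 nM in an ADME assay on CCRF-CEM cells (Homo sapiens) for antiproliferative activity, with a stated time of 48 h; a higher number here means a weaker inhibitor, a lower number a stronger inhibitor. Compound 2 `C=C(Br)C(=O)Nc1ccc(C(=O)/C=C/c2ccc(OC)cc2)cc1` differs from it by methoxy in place of hydrogen on an aromatic carbon, and in this assay compound 2 gives 1100 nM, a step of a 1.4-fold lower number from compound 1 to compound 2 (0.13 log units; within the scatter). Compound 3 `C=C(Br)C(=O)Nc1ccc(C(=O)/C=C/c2cc(OC)cc(OC)c2)cc1` gives 2200 nM; how its core differs from that of compound 1 is not broken down here. Compound 4 `C=C(Br)C(=O)Nc1ccc(C(=O)/C=C/c2cc(OC)c(OC)c(OC)c2)cc1` differs from compound 3 by methoxy in place of hydrogen on an aromatic carbon, the same kind of change as that from compound 1 to compound 2, though here the entering group sits ortho to two methoxy groups as well as para to a large group. Because the earlier step of a 1.4-fold lower number from compound 1 to compound 2 (0.13 log units; within the scatter) stayed within the scatter, compound 4 is expected to show a step of a 1.2-fold lower number from compound 3 to compound 4 (0.09 log units; within the scatter) from compound 3. Compound 4 is therefore estimated at 1800 nM, between 900 nM and 3600 nM.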

Compound 4, half-maximal inhibitory concentration: 330 nM
Estimate against measurement, compound 4: 5.5-fold (0.74 log units) above; the measured number lies below the stated range.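

In this assay, methoxy in place of hydrogen on an aromatic carbon brings a 6.7-fold lower number from compound 3 to compound 4 (0.82 log units; beyond the scatter), a larger step than the one seen on the core of compound 1. The size of this change therefore did not carry over unchanged from one core to the other: the same change on two cores in this assay, a 1.4-fold lower number (0.13 log units; within the scatter) from compound 1 to compound 2 and a 6.7-fold lower number (0.82 log units; beyond the scatter) from compound 3 to compound 4, 4.9-fold (0.69 log units) apart, beyond the scatter of two such steps. Among these compounds, this comparison rests on only two pairs, and it does not show why the steps differ or whether the entering group's place, ortho to two methoxy groups, matters more than the rest of the core.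

The compounds shown leave open how a hydroxyl, an amine or an ethoxy group would behave at that place. They also leave open whether the lower number of compound 4 would survive replacing either neighbouring methoxy group with a chlorine.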